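Swapping 3,4-difluorophenyl for 3-chlorophenyl on the shared core

This account rests on a few compounds, and the source may have more. Where it says the series, first, only, none or still open, it means among the compounds named here.

In a functional assay on MCF7 cells (Homo sapiens) for inhibition, read by sulforhodamine B assay, with a stated time of 48 h (on this read-out lower numbers stand for stronger inhibition of growth and higher numbers for weaker inhibition of growth), compound 3 (`CN1CCN(CCCOc2cccc3nc(Nc4ccc(F)c(F)c4)ccc23)CC1`) gives 3330 nM. This sits within the scatter of compound 2 (`CC(C)c1ccc(Nc2ccc3c(OCCCN4CCN(C)CC4)cccc3n2)cc1`), which gives 3210 nM, as a 1.0-fold higher number from compound 2 to compound 3 (0.02 log units; within the scatter) shows. Compound 1 (`CN1CCN(CCCOc2cccc3nc(Nc4ccc(Cl)c(C(F)(F)F)c4)ccc23)CC1`) gives 1410 nM, and a 2.4-fold higher number from compound 1 to compound 3 (0.37 log units; beyond the scatter) lies beyond the scatter, as does a 2.3-fold higher number from compound 1 to compound 2 (0.36 log units; beyond the scatter).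

Compound 4 (`CN1CCN(CCCOc2cccc3nc(Nc4cccc(Cl)c4)ccc23)CC1`) keeps the core of compound 3 and carries 3-chlorophenyl in place of 3,4-difluorophenyl on a nitrogen on an aromatic ring.

For the measured compounds named here, no measured step makes this exact exchange, so the evidence is indirect. The three groups measured so far differ on that same nitrogen, and their steps are no more than modest. Going by the values given here, compound 1, at 1410 nM, is the only measured compound with chlorine in this group, but its 4-chloro-3-(trifluoromethyl)phenyl also carries a trifluoromethyl group, so it is only a partial guide. A small move from compound 3 toward compound 1 therefore seems reasonable, though no step beyond the scatter is expected. The estimated step is a 1.4-fold lower number from compound 3 to compound 4 (0.14 log units; within the scatter). For compound 4 the expected value is 2400 nM, with an estimated range from 1200 nM to 4800 nM.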

Compound 4, concentration for 50% growth inhibition: 1570 nM
Estimate against measurement, compound 4: 1.5-fold (0.18 log units) above; the measured number falls inside the stated range.
By their numbers in this assay, from the lowest: compounds 1 and 4 (each within the scatter of the next); then compounds 2 and 3 (each within the scatter of the next).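

In this assay, a 2.1-fold lower number from compound 3 to compound 4 (0.33 log units; beyond the scatter) and a 2.0-fold lower number from compound 2 to compound 4 (0.31 log units; beyond the scatter) both lie beyond the scatter, so on this nitrogen on an aromatic ring, 3-chlorophenyl separates from both 3,4-difluorophenyl and 4-isopropylphenyl. By contrast, a 1.1-fold higher number from compound 1 to compound 4 (0.05 log units; within the scatter) lies within the scatter, which shows that a group with chlorine and no trifluoromethyl can match 4-chloro-3-(trifluoromethyl)phenyl, the group that had stood apart from the other two. Among these four compounds, the two groups carrying chlorine form the lower pair and the two without it form the higher pair, with no compound going against this, although the steps are modest at most and no measurement given here accounts for the split.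

The compounds shown leave open how an unsubstituted phenyl, 4-chlorophenyl or 3-bromophenyl would read on the same nitrogen, so the contribution of chlorine cannot yet be separated from that of its place on the ring or of a halogen in general. From the compounds shown here alone, every compound also keeps the rest of the shared core unchanged, so it remains open whether a longer chain or a different amine there would shift these steps.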